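Linker Methyl Step from Compound 3 to Compound 4

The source may report more compounds than this note shows. Statements on the series, on what has been measured and on what is new or still open speak of the compounds shown alone.

Three members of the series have been measured in a functional assay on MDA-MB-231 cells (Homo sapiens) for inhibition, read by MTT assay, with a stated time of 72 h; on this read-out lower numbers stand for stronger inhibition and higher numbers for weaker inhibition. Compound 1 `CC1=C(C(C)CC(=O)OCC(C)COc2no[n+]([O-])c2S(=O)(=O)c2ccccc2)C(=O)c2c(O)cccc2C1=O` gives 2110 nM and compound 2 `CC1=C(CCCC(=O)OCCOc2no[n+]([O-])c2S(=O)(=O)c2ccccc2)C(=O)c2c(O)cccc2C1=O` gives 1520 nM. Compound 3 `CC1=C(CCC(=O)OCCCOc2no[n+]([O-])c2S(=O)(=O)c2ccccc2)C(=O)c2c(O)cccc2C1=O` gives 4310 nM, the highest of the three numbers; the gap to compound 1 and the gap to compound 2 both lie beyond the scatter of repeated measurements, so compound 3 is the weakest inhibitor among the measured set on this read-out.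

Compound 4 `CC1=C(CCC(=O)OCC(C)COc2no[n+]([O-])c2S(=O)(=O)c2ccccc2)C(=O)c2c(O)cccc2C1=O` has not yet been measured. It differs from compound 3 by methyl in place of hydrogen on a saturated chain carbon bound to two saturated chain carbons. For the measured compounds named here, no measured pair in the set isolates this single change, so its size and direction cannot be taken from the data; the nearest comparison is compound 1, which carries a branched linker as well but also differs from compound 4 in its other chain. In this assay compound 1 gives 2110 nM.

Going by the values given here, with no direct precedent, the expected step of a 1.3-fold lower number from compound 3 to compound 4 (0.13 log units; within the scatter) is small, at most a modest lowering of the number, and may well fall within the scatter. On that basis compound 4 is estimated at 3200 nM in this assay, with a plausible range from 1300 nM to 8000 nM.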

Compound 4, half-maximal inhibitory concentration: 2670 nM
Beside the measured number, compound 4's estimate is 1.2-fold (0.08 log units) above it, within the range that was stated.
By their numbers in this assay, from the lowest: compounds 2, 1, 4 and 3 (each within the scatter of the next, the first and the last beyond it).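

In this assay, for the compounds shown here, methyl in place of hydrogen on a saturated chain carbon bound to two saturated chain carbons gives a 1.6-fold lower number from compound 3 to compound 4 (0.21 log units; within the scatter) as a single change, the first reading at this position, and the methyl is tolerated there without a step beyond the scatter. The second branching point can now also be read alone: hydrogen in place of methyl on a saturated chain carbon bound to a double-bonded ring carbon and a saturated chain carbon gives a 1.3-fold higher number from compound 1 to compound 4 (0.10 log units; within the scatter) and so also stays inside the scatter. No accompanying data bear on why either step has the size it has.

On these data alone, both readings cover only methyl against hydrogen, so the effect of an ethyl group, a hydroxyl group or an amine on the same saturated chain carbon remains open. Also open, as far as these compounds go, is the step from compound 3 for methyl placed only on the chain carbon bound to the double-bonded ring carbon, and with it whether the two methyl groups act independently.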